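This account rests on a few compounds, and the source may have more. Where it says the series, first, only, none or still open, it means among the compounds named here.

Measured compounds:
compound 1 `Cc1cccc(N2CCC(C(=O)Nc3ccc4c(c3)NC(=O)CO4)CC2)c1` — 490 nM
compound 2 `O=C(Nc1ccc2cc[nH]c2c1)C1CCN(c2cccc(C(F)(F)F)c2)CC1` — > 9000 nM

In a functional assay for antagonist activity at transient receptor potential cation channel subfamily V member 1 (Homo sapiens), read by FLIPR and calcium flux (on this read-out higher numbers stand for weaker inhibition and lower numbers for stronger inhibition), compound 1 gives 490 nM. Compound 2 is reported only as > 9000 nM, which is a limit of the assay and not a number. Compound 2 therefore sits at the limit of > 9000 nM in this assay, at which 1 of the 2 values shown sits, and no firmer position can be given for it. Compound 3 `O=C(Nc1cccc2[nH]ccc12)C1CCN(c2cccc(C(F)(F)F)c2)CC1` differs from compound 2 by 1H-indol-4-yl in place of 1H-indol-6-yl on an amide-type nitrogen. Within the data shown here, no measured pair shows this change, so its direction is open; the step from compound 2 to compound 3 is expected to be an at least 1.2-fold lower number from compound 2 to compound 3 (0.10 log units; that floor lies within the scatter), not beyond the scatter around a value at the limit. Compound 3 is therefore expected to give 7000 nM, between 1500 nM and 20000 nM.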

Compound 3, half-maximal inhibitory concentration: 230 nM
Compound 3: middle estimate off by 30-fold (1.48 log units), on the high side, outside the stated range (below it).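

Exchanging 1H-indol-6-yl for 1H-indol-4-yl on an amide-type nitrogen, with the same atoms joined differently, gives an at least 39-fold lower number from compound 2 to compound 3 (1.59 log units; beyond the scatter) in this assay. Among these compounds, no earlier pair showed a change in one place, and this one shows that the point at which the indole is joined can by itself carry a large step. The value of compound 2 is a limit, so the step has a floor and no exact size: the limit of > 9000 nM in this assay, at which 1 of the 3 values shown sits.

The compounds shown leave open what 1H-indol-5-yl or 1H-indol-7-yl would give on that amide-type nitrogen. They also leave open whether the step holds with a methyl group in place of trifluoromethyl.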